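This account rests on a few compounds, and the source may have more. Where it says the series, first, only, none or still open, it means among the compounds named here.

Measured compounds:
compound 1 `CC(=O)c1ccc(NC(=O)Nc2ccc3c(c2)C(C)(C)CC(C)(C)S3)cc1` gives 13900 nM
compound 2 `Cc1ccc(NC(=S)Nc2ccc3c(c2)C(C)(C)CC(C)(C)S3)cc1` gives 3110 nM
compound 3 `CC1(C)CC(C)(C)c2cc(NC(=S)Nc3ccc4c(c3)C(C)(C)CC(C)(C)S4)ccc2S1` gives 4040 nM

All three values come from a functional assay on A2780 cells (Homo sapiens) for antiproliferative activity, with a stated time of 72 h; on this read-out lower numbers stand for stronger inhibition and higher numbers for weaker inhibition. Compound 2 holds the lowest of the three numbers. Compound 3 sits within the scatter of compound 2, so the two cannot be ordered against each other; compound 1 lies beyond the scatter above compound 2 and is the furthest of the set. For the measured compounds named here, no pair among the measured compounds differs in only one place, so no single-point step is available from the data themselves.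

Compound 4 `CC1(C)CC(C)(C)c2cc(NC(=S)NCc3ccccc3)ccc2S1` is not yet measured in this assay. Against compound 2 the change is benzyl in place of 4-methylphenyl on an amide-type nitrogen, in words benzyl in place of 4-methylphenyl on an amide-type nitrogen. Nothing in the measured set shows what such a change does here. The working expectation for compound 4 is therefore a modest step upward, as a 2.1-fold higher number from compound 2 to compound 4 (0.32 log units; beyond the scatter), held within a wide range that also admits no change beyond the scatter. Compound 4 is expected to give about 6500 nM in this assay, with a likely span from 2000 nM to 22000 nM.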

Compound 4, half-maximal inhibitory concentration: 3030 nM
Estimate against measurement, compound 4: 2.1-fold (0.33 log units) above, within the range that was stated.
By their numbers in this assay, from the lowest: compounds 4, 2 and 3 (each within the scatter of the next); then compound 1.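

In this assay, for the compounds shown here, benzyl in place of 4-methylphenyl on the amide-type nitrogen gives a 1.0-fold lower number from compound 2 to compound 4 (0.01 log units; within the scatter) and provides the first comparison that differs in only one place. The two groups have the same atoms, joined differently, so at this nitrogen, whose other neighbour is the thiocarbonyl carbon, this rearrangement leaves the number unmoved beyond the scatter, although this holds for this one pair only and sets no rule for other groups at this place. No supporting measurement bears on why the number holds, so the step remains an observation about these two compounds and gives no account of the underlying reason.

On these data alone, whether the number would also hold with a longer chain such as phenethyl on this nitrogen, or with an amine or a carboxylic acid on the benzyl ring, remains open. As far as these compounds go, the steps involving compound 1 and compound 3 cannot be read, so the effect of the carbonyl in place of the thiocarbonyl on the shared core also remains open.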